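The compounds below may be only part of what the source reports. "The series", "measured", "known", "first", "only" and "open" are said of these compounds alone.

Measured values in a functional assay on EC9706 cells (Homo sapiens) for cytotoxicity, read by MTT assay, with a stated time of 72 h; on this read-out higher numbers stand for weaker inhibition and lower numbers for stronger inhibition:
- compound 1 `CCNC(=O)N1CCN(C(=S)SCc2cn(Cc3ccccc3F)nn2)CC1`: 23700 nM
- compound 2 `CC(C)NC(=O)N1CCN(C(=S)SCc2cn(Cc3ccccc3F)nn2)CC1`: 20800 nM
- compound 3 `CCNC(=O)N1CCN(C(=S)SCc2cn(Cc3ccc(F)cc3)nn2)CC1`: 27800 nM

Compound 3 carries the largest of the three numbers, but only narrowly: the step of a 1.2-fold higher number from compound 1 to compound 3 (0.07 log units; within the scatter) is within the scatter, and the values of compound 2 and compound 3 likewise lie within the usual scatter of each other. On present evidence the three compounds cannot be separated.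

Compound 4 `O=C(NC1CCCCC1)N1CCN(C(=S)SCc2cn(Cc3ccc(F)cc3)nn2)CC1` follows from compound 3 by the change (cyclohexyl in place of ethyl on an amide-type nitrogen). Among the measured compounds shown here, only one measured step touches the carbamoyl substituent: a 1.1-fold lower number from compound 1 to compound 2 (0.06 log units; within the scatter), which adds a single carbon at the chain bound to the amide-type nitrogen and stays within the scatter. The ring-swap step a 1.2-fold higher number from compound 1 to compound 3 (0.07 log units; within the scatter) is also within the scatter and concerns a different part of the core. For the measured compounds named here, no measured pair covers a change as large as ethyl to cyclohexyl on the amide-type nitrogen, so the expectation rests on the flat behaviour of the series so far.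

The step of a 1.3-fold lower number from compound 3 to compound 4 (0.10 log units; within the scatter) is therefore expected to be small, with no clear direction beyond the scatter. Compound 4 is estimated at 22000 nM in this assay, within a range of 8000 nM to 60000 nM, the range widened to reflect the untested size of the change.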

Compound 4, half-maximal inhibitory concentration: > 128000 nM
Compound 4 was reported as a limit (the forecaster's own chance of this, stated with the estimate: 10%); middle value at least 5.8-fold (0.76 log units) away from the limit.
By their numbers in this assay, from the lowest: compounds 2, 1 and 3 (each within the scatter of the next). At a limit, above all of these: compound 4.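

In this assay, among the compounds shown here, the substituent on the amide-type nitrogen is the first place where a change moves the read-out beyond the scatter: cyclohexyl in place of ethyl gives an at least 4.6-fold higher number from compound 3 to compound 4 (0.66 log units; beyond the scatter). The value of compound 4 is a limit and not a number, so the full size of this step stays unknown: the limit of > 128000 nM in this assay, at which 1 of the 4 values shown sits.

For the compounds shown here, the only earlier change at this place, a 1.1-fold lower number from compound 1 to compound 2 (0.06 log units; within the scatter), was small and stayed within the scatter, so the flat behaviour seen there does not hold for every substituent on this nitrogen.

Open, from the compounds shown here alone, is whether the step goes with the ring itself or with the larger number of carbons, a question that a longer chain such as hexyl or a smaller ring such as cyclopropyl on the same nitrogen would separate. Also open, going by these compounds, is whether cyclohexyl gives the same result with 2-fluorophenyl in place of 4-fluorophenyl, and whether a group such as aminoethyl or hydroxyethyl at this place could bring the number below those of compound 1, compound 2 and compound 3.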